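A few compounds are considered here, and "the series" means these few. Any claim that something is new, unique, unknown or untested is made for them only; others in the source may bear on it.

Three compounds that share a naphthyloxy-substituted, hydroxylated saturated six-membered ring were examined in an ADME assay on CCD-1095SK cells (Homo sapiens) for antiproliferative activity, read by crystal violet staining, with a stated time of 96 h; a higher number here means that more compound is needed for the effect, a lower number that less compound is needed. Compound 1 `O[C@@H]1[C@@H](O)[C@H](Oc2ccc3ccccc3c2)OC[C@H]1F` gives 32 uM. Compound 2 `O[C@@H]1CO[C@@H](Oc2ccc3ccccc3c2)C[C@H]1O` gives 19 uM. Compound 3 `O[C@@H]1[C@@H](F)[C@H](Oc2ccc3ccccc3c2)OC[C@H]1O` gives 12 uM. Compound 1 has the highest of the three numbers; its gap to compound 2 lies within the scatter, while its gap to compound 3 lies beyond it. Compound 1 and compound 3 have the same atoms joined differently, and the difference between the two cores is not broken down here.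

Compound 3 and compound 2 differ in one place, (hydrogen in place of fluoro on a saturated ring carbon), and this gives a 1.6-fold higher number from compound 3 to compound 2 (0.20 log units; within the scatter), a step that stays within the scatter.

Compound 4 `O[C@H]1[C@H](Oc2ccc3ccccc3c2)OCC[C@@H]1O` is not yet measured. It differs from compound 1 by hydrogen in place of fluoro on a saturated ring carbon. This is the same kind of change as that from compound 3 to compound 2, but the surroundings are not identical: in the measured pair the carbon is next to the ring atom that bears a large group, whereas in compound 4 it is three ring bonds from the ring atom that bears a large group. Because a 1.6-fold higher number from compound 3 to compound 2 (0.20 log units; within the scatter) was small, the account expects a step of similar size, a 1.1-fold higher number from compound 1 to compound 4 (0.04 log units; within the scatter), for compound 4. The estimate for compound 4 in this assay is therefore 35 uM, with an expected range from 15 uM to 80 uM.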

Compound 4, concentration for half-maximal effect: 285 uM
The estimate for compound 4 lay 8.1-fold (0.91 log units) below the measured number; the measured number lies above the stated range.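

Replacing the fluoro group with hydrogen on the saturated ring carbon gives an 8.9-fold higher number from compound 1 to compound 4 (0.95 log units; beyond the scatter) in this assay, so this change cannot be treated as a small step throughout the series. Its size did not carry over from one core to the other, and the earlier step is a poor guide to the new one: the same change on two cores in this assay, a 1.6-fold higher number (0.20 log units; within the scatter) from compound 3 to compound 2 and an 8.9-fold higher number (0.95 log units; beyond the scatter) from compound 1 to compound 4, 5.6-fold (0.75 log units) apart, beyond the scatter of two such steps

What this does not show is why the two steps part. Among the compounds shown here, there are only two pairs, and in compound 1 the fluoro group stands three ring bonds from the ring atom that bears a large group, a place it does not hold in compound 3, so its place and the rest of the core cannot be separated as the source of the gap.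

The compounds shown leave open whether a hydroxy group, a methoxy group or an amine in the place of that fluoro group on the core of compound 1 would keep the number near that of compound 1 or move it towards that of compound 4. They also leave open whether the gap between the two steps would persist on a further core, or with a group other than naphthyloxy as the large group.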